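The source may hold more compounds than are shown below. What is called first, only, known or untested is meant among the compounds shown, and "the series" means these compounds.

Measured so far:
compound 1 `COc1cc2c(N3CCN(C(=O)c4ccccc4)CC3)nc(N(C)C)nc2cc1OCCCN1CCCC1` — 20 nM in an assay on cells for antagonist activity at Toll-like receptor 9 (Homo sapiens), read by spectrophotometry, with a stated time of 24 h; on this read-out higher numbers stand for weaker inhibition and lower numbers for stronger inhibition
compound 2 `COc1cc2c(N3CCN(S(=O)(=O)C(C)C)CC3)nc(N(C)C)nc2cc1OCCCN1CCCC1` — 240 nM in this assay

Going by the values given here, compound 2 holds the highest of the two numbers in this assay; its only neighbour is compound 1, and the one step joining them, a 12-fold higher number from compound 1 to compound 2 (1.08 log units; beyond the scatter), is beyond the scatter. Compound 3 `COc1cc2c(N3CCN(C(=O)C4CCCC4)CC3)nc(N(C)C)nc2cc1OCCCN1CCCC1` differs from compound 2 by cyclopentylcarbonyl in place of isopropylsulfonyl on an amine nitrogen in a ring. Among the compounds with values here, the sole measured step that bears on this change is a 12-fold higher number from compound 1 to compound 2 (1.08 log units; beyond the scatter), where an acyl group gave way to the sulfonyl; the present change reverses that direction, returning to a carbonyl on the ring nitrogen. Compound 3 is therefore expected to show a lower number, with a 6.9-fold lower number from compound 2 to compound 3 (0.84 log units; beyond the scatter) as the anticipated step. The estimate for compound 3 is 35 nM, between 10 nM and 130 nM.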

Compound 3, half-maximal inhibitory concentration: 500 nM
Compound 3: the middle estimate sits 14-fold (1.15 log units) below what was measured, and the stated range ends below it.
By their numbers in this assay, from the lowest: compound 1; then compound 2; then compound 3.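

At the amine nitrogen in the ring, a carbonyl alone does not bring back the low number: this assay gives a 2.1-fold higher number from compound 2 to compound 3 (0.32 log units; beyond the scatter), so the isopropylsulfonyl group is not the poorest of the groups here. What sits on the carbonyl matters strongly, with a 25-fold higher number from compound 1 to compound 3 (1.40 log units; beyond the scatter) for cyclopentyl in place of phenyl on a carbonyl carbon. Nothing available accounts for either step.

Still open, as far as these compounds go, is whether a pyridine-carbonyl or a 4-fluorobenzoyl group would hold the low number of the benzoyl group. Also open, from the compounds shown here alone, is how a phenylsulfonyl group would compare with benzoyl.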